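The source may report more compounds than this note shows. Statements on the series, on what has been measured and on what is new or still open speak of the compounds shown alone.

Compound 1 `C#CCNC1CCc2c(SCc3cccc(C)c3)cccc21`: in an ADME assay on isolated protein for inhibition of Amine oxidase [flavin-containing] B (Homo sapiens) (a lower number here means a stronger inhibitor, a higher number a weaker inhibitor), compound 1 gives > 100000 nM, which is a limit of the assay.
Compound 2 `C#CCNC1CCc2c(SCc3ccc(Br)cc3)cccc21`: in this assay compound 2 gives 488 nM.
Compound 3 `C#CCNC1CCc2c(SCc3ccccc3)cccc21`: in this assay compound 3 is reported as "not active" (no number reported), with no number.

Compound 3 therefore stands without a number; of the three values shown, one sits at a limit (the limit of > 100000 nM in this assay, at which 1 of the 3 values shown sits). Compound 4 `C#CCNC1CCc2c(SCc3cccc(Cl)c3)cccc21` differs from compound 3 by chloro in place of hydrogen on an aromatic carbon. For the measured compounds named here, the only measured step, an at least 200-fold lower number from compound 1 to compound 2 (2.31 log units; beyond the scatter), compares two substituted phenyl groups and does not start from the unsubstituted phenyl of compound 3, so no step measures the addition of a single ring substituent. Compound 1 and compound 3 both give weak or no inhibition, and compound 4 is accordingly expected to remain weak, estimated at 60000 nM (5000 nM to 300000 nM), possibly reported only as a limit.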

Compound 4, half-maximal inhibitory concentration: 1090 nM
Estimate against measurement, compound 4: 55-fold (1.74 log units) above, outside the stated range (below it).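

Chloro in place of methyl on an aromatic carbon turns a compound at the assay limit into a measurable inhibitor in this assay, with an at least 91-fold lower number from compound 1 to compound 4 (1.96 log units; beyond the scatter). This step rests on compound 1, whose value is a limit and not a number: the limit of > 100000 nM in this assay, at which 1 of the 4 values shown sits. Activity is therefore not confined to 4-bromophenyl, as 3-chlorophenyl stays close to it, with a 2.2-fold higher number from compound 2 to compound 4 (0.35 log units; beyond the scatter).

Compound 3 has no number, so the gain from chloro over hydrogen cannot be sized. Going by these compounds, how a methoxy group or a nitrile would read in place of the chloro remains open.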